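A few compounds are considered here, and "the series" means these few. Any claim that something is new, unique, unknown or untested is made for them only; others in the source may bear on it.

Measured in a functional assay on RAW264.7 cells (Mus musculus) for inhibition, read by fluorescence, with stated times of 1 h, 24 h and 30 min (on this read-out lower numbers stand for stronger inhibition and higher numbers for weaker inhibition), all three values being limits of the assay:
Compound 1 `O=C(/C=C/c1cccc(F)c1)c1ccccc1`: > 10000 nM
Compound 2 `O=C(/C=C/c1ccc(C(F)(F)F)cc1)c1ccc(O)cc1`: > 10000 nM
Compound 3 `O=C(/C=C/c1cccc(OC(F)(F)F)c1)c1ccccc1`: > 10000 nM

Compound 3 stands on (the limit of > 10000 nM in this assay, at which 3 of the 3 values shown sit). Compound 4 `O=C(/C=C/c1cccc(OC(F)(F)F)c1)c1ccc(O)cc1` places hydroxy in place of hydrogen on an aromatic carbon, para to a large group, so that phenyl becomes 4-hydroxyphenyl: hydroxy in place of hydrogen on an aromatic carbon.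

Among the compounds with values here, the only measured step, a step that the two limits leave unreadable from compound 1 to compound 3, concerns a different change and gives no size to carry over. Compound 2 already has the 4-hydroxyphenyl and gives > 10000 nM, which is again a limit. Within the data shown here, no measured step therefore shows what the hydroxy does, and no large gain is expected in this assay. A result at the limit remains more likely than not. If a number is reported, the expected step, an at least 1.2-fold lower number from compound 3 to compound 4 (0.09 log units; that floor lies within the scatter), is small and towards stronger inhibition. For compound 4 the estimate is 8000 nM, with an expected range from 2500 nM to 20000 nM.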

Compound 4, half-maximal inhibitory concentration: > 10000 nM
Compound 4 ended at the assay's limit; the forecaster's own chance of this, stated with the estimate: 60%; at least 1.2-fold (0.09 log units) between middle value and limit.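

In this assay compound 4 gives > 10000 nM, a limit of the assay and not a number, so no step can be read between compound 3 and compound 4. The compounds shown leave open what the hydroxy does to inhibition, and which change to the shared core would give a measurable number: the limit of > 10000 nM in this assay, at which 4 of the 4 values shown sit.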